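The source may report more compounds than this note shows. Statements on the series, on what has been measured and on what is new or still open speak of the compounds shown alone.

Measured so far in an assay on HEK293 cells for inhibition of steroid 17-alpha-hydroxylase/17,20 lyase (Homo sapiens), read by scintillation proximity assay, using microsomes and NADPH, with a stated time of 45 min; on this read-out higher numbers stand for weaker inhibition and lower numbers for stronger inhibition:

compound 1 `Cc1ccncc1-c1cccc2c1cnn2-c1cccnn1` gives 3 nM
compound 2 `Cc1ccncc1-c1cccc2c1ncn2-c1cscn1` gives 8 nM

Compound 1 stands lowest of the two numbers in this assay. Its nearest neighbour is compound 2, whose number is higher by a margin beyond the usual scatter, so on these two values compound 1 is the stronger inhibitor. Going by the values given here, no single-point step between the two measured compounds is available, since they differ in more than one place.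

Compound 3 `Cc1ccncc1-c1cccc2c1cnn2-c1ccccn1` has not yet been measured. It differs from compound 1 in one place only: pyridin-2-yl in place of pyridazin-3-yl on an aromatic nitrogen. Both the leaving and the entering group are six-membered aromatic rings of the same size, so the change is small. Compound 3 is expected to land close to compound 1, with a step of a 1.3-fold higher number from compound 1 to compound 3 (0.12 log units; within the scatter) that stays within the scatter. Compound 3 is therefore estimated at 4 nM, in a range from 1.5 nM to 12 nM.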

Compound 3, half-maximal inhibitory concentration: 2 nM
Compound 3: the middle estimate sits 2.0-fold (0.30 log units) above what was measured, within the range that was stated.
By their numbers in this assay, from the lowest: compounds 3 and 1 (each within the scatter of the next); then compound 2.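

In this assay, the exchange of pyridazin-3-yl for pyridin-2-yl on an aromatic nitrogen gives a step that stays within the scatter (a 1.5-fold lower number from compound 1 to compound 3 (0.18 log units; within the scatter)), so compound 1 and compound 3 cannot be told apart. This position therefore accepts the loss of one ring nitrogen, and of one hydrogen-bond acceptor by the count, with no step beyond the scatter on this read-out. Nothing at hand explains why this exchange makes so little difference.

On the core of compound 1, only these two six-membered aromatic rings are shown at this position, so it remains open whether a phenyl ring, with no ring nitrogen, or a non-aromatic group such as an amine would hold the number. As far as these compounds go, it also remains open whether the same exchange would read alike on the core of compound 2.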